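The source may report more compounds than this note shows. Statements on the series, on what has been measured and on what is new or still open speak of the compounds shown alone.

Measured compounds:
- compound 1, `OC[C@H]1O[C@@H](n2cnc3c(NCc4ccc(Cl)cc4Cl)ncnc32)[C@H](O)[C@@H]1O`: > 166000 nM
- compound 2, `COc1cc(CNc2ncnc3c2ncn3[C@@H]2O[C@H](CO)[C@@H](O)[C@H]2O)cc(OC)c1O`: "not determined" (no result reported)
- compound 3, `COc1cc(O)cc(OC)c1CNc1ncnc2c1ncn2[C@@H]1O[C@H](CO)[C@@H](O)[C@H]1O`: "not determined" (no result reported)

The read-out here is a functional assay on B16 cells (Mus musculus) for antiproliferative activity, with a stated time of 72 h; on this read-out lower numbers stand for stronger inhibition and higher numbers for weaker inhibition. Compound 1 gives only a limit in this assay, > 166000 nM, which is the edge of what the assay reports rather than a number; this is the limit of > 166000 nM in this assay, at which 1 of the 3 values shown sits. For compound 2 the result in this assay is "not determined" (no result reported), and for compound 3 it is "not determined" (no result reported), so neither adds a number to compare against. Among the compounds with values here, no pair of measured compounds differs in a single place, so no measured step can be quoted.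

Compound 4, `Cc1ccc(O)c(CNc2ncnc3c2ncn3[C@@H]2O[C@H](CO)[C@@H](O)[C@H]2O)c1`, is still to be measured. It differs from compound 1 in one place: 2-hydroxy-5-methylphenyl in place of 2,4-dichlorophenyl on a saturated chain carbon bound to a nitrogen on an aromatic ring. Within the data shown here, since compound 1 sits at the limit of this assay, there is no measured step to anchor a direction. The expectation is that the step of an at least 1.1-fold lower number from compound 1 to compound 4 (0.04 log units; that floor lies within the scatter) is small and most likely within the scatter, with compound 4 again near or at the limit. Compound 4 is estimated at 150000 nM in this assay, between 30000 nM and 200000 nM.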

Compound 4, half-maximal inhibitory concentration: > 166000 nM
Compound 4: a limit, no number (the forecaster's own chance of this, stated with the estimate: 70%); middle value at least 1.1-fold (0.04 log units) from the limit.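

Compound 1 and compound 4 each stop at a limit of the assay rather than a number, so no step between them can be read: the limit of > 166000 nM in this assay, at which 2 of the 4 values shown sit.

The compounds shown leave open whether any group in place of 2,4-dichlorophenyl would give a real number in this assay.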